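Fluoro in place of butyl on the amino-bearing ring

The compounds below may be only part of what the source reports. "The series", "measured", "known", "first", "only" and "open" are said of these compounds alone.

Three measured compounds share a benzyl group carrying fluorine on a fused bicyclic core. Compound 1 `OCc1ccc(-c2nn(Cc3ccccc3F)c3ccccc23)o1` gives 4900 nM; 4900 nM (2 entries) in a functional assay (aorta) with Oryctolagus cuniculus as the target (on this read-out lower numbers stand for stronger inhibition and higher numbers for weaker inhibition), recorded as two entries. Compound 2 `Fc1ccccc1Cn1nc(-c2ccco2)c2cccnc21` gives 9300 nM in this assay. Compound 3 `CCCCc1cnc(-c2nn(Cc3ccccc3F)c3ncccc23)nc1N` carries an amino-substituted six-membered ring with two nitrogens in place of the furan and gives 218000 nM in this assay, the highest number among the measured compounds; the nearest value, that of compound 2, is lower by a gap beyond the scatter.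

Compound 4 `Nc1nc(-c2nn(Cc3ccccc3F)c3ncccc23)ncc1F` differs from compound 3 in one place: fluoro in place of butyl on an aromatic carbon. Going by the values given here, no step between measured compounds isolates this change, so the account rests on compound 3 alone. A step of modest size toward a lower number is expected for a 1.8-fold lower number from compound 3 to compound 4 (0.26 log units; within the scatter), though a result within the scatter would not be surprising. Compound 4 is therefore estimated at 120000 nM in this assay, with a range from 35000 nM to 450000 nM.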

Compound 4, half-maximal inhibitory concentration: 478000 nM
Compound 4: middle estimate off by 4.0-fold (0.60 log units), on the low side; measured number above the stated range.
By their numbers in this assay, from the lowest: compound 2; then compound 3; then compound 4.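

In this assay, fluoro in place of butyl on the aromatic carbon ortho to the amino group gives a 2.2-fold higher number from compound 3 to compound 4 (0.34 log units; beyond the scatter) and so moves the number further up, which shows that removing the butyl chain recovers nothing at this position. The larger change is the exchange of the whole group, since 4-amino-5-fluoropyrimidin-2-yl in place of furan-2-yl gives a 51-fold higher number from compound 2 to compound 4 (1.71 log units; beyond the scatter) and dwarfs the step from butyl to fluoro. No measurement shown here accounts for either step. The compounds shown leave open whether a methyl or methoxy group on this same carbon would give a lower number than butyl or fluoro. They also leave open whether a hydroxymethyl group on this ring, as carried by the furan of compound 1, would bring the number down.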